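Fluoro on the Aromatic Ring of the Compound 1 Core

This account rests on a few compounds, and the source may have more. Where it says the series, first, only, none or still open, it means among the compounds named here.

Compound 1 `CC1(C)COc2ccccc2C1O` — 24.3%
Compound 2 `CC1(C)COc2ccccc2C1N` — -3.8%
Compound 3 `COc1cccc2c1C(O)C(C)(C)CO2` — 11.5%

In an assay on BTI cells for inhibition of Amine oxidase [flavin-containing] A (Homo sapiens), read by fluorescence, with a stated time of 20 min, tested at 1 uM (on this read-out lower numbers stand for less inhibition and higher numbers for more inhibition at the one concentration tested (going by the name of the read-out)), compound 1 stands highest of the three numbers shown; compound 3 is the nearest of the others, compound 2 the furthest. Compound 4 `CC1(C)COc2ccc(F)cc2C1O` differs from compound 1 by fluoro in place of hydrogen on an aromatic carbon. The measured step that bears most on this is a number 12.8 percentage points lower from compound 1 to compound 3 (beyond the scatter), which is likewise a change on an aromatic carbon of the shared core. The other step, a number 28.1 percentage points lower from compound 1 to compound 2 (beyond the scatter), concerns a saturated ring carbon and speaks less to this change. A modest fall, or no change beyond the scatter, is therefore expected, a number 8.3 percentage points lower from compound 1 to compound 4 (within the scatter). Compound 4 is estimated at 16%, with a range from 2% to 30%.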

Compound 4, a percentage reported as inhibition, at one concentration (the size of the read-out at that concentration, not a potency): 16.5%
Compound 4: the middle estimate sits 0.5 percentage points below what was measured; the measured number falls inside the stated range.
By their numbers in this assay, from the lowest: compound 2; then compounds 3, 4 and 1 (each within the scatter of the next, the first and the last beyond it).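

In this assay, fluoro in place of hydrogen on this aromatic carbon, meta to a fused ring and para to a fused ring, gives a number 7.8 percentage points lower from compound 1 to compound 4 (within the scatter), so this change stays within the scatter. The earlier methoxy change, a number 12.8 percentage points lower from compound 1 to compound 3 (beyond the scatter), lay beyond it, so not every aromatic substitution on the shared core shifts the number beyond the scatter. Nothing available explains this result. From the compounds shown here alone, whether chloro, methoxy or a carboxylic acid on this same carbon would also stay within the scatter remains open.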